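The source may hold more compounds than are shown below. What is called first, only, known or untested is meant among the compounds shown, and "the series" means these compounds.

Measured in a functional assay on cells (Tumor Cell line, Homo sapiens) for antiproliferative activity; on this read-out higher numbers stand for weaker inhibition of growth and lower numbers for stronger inhibition of growth:
- compound 1 `Cc1cccc(-c2cc(O)c3ccc(C)nc3n2)c1`: 97.7 nM
- compound 2 `Cc1cc(C)c2c(O)cc(-c3cccc(F)c3)nc2n1`: 85.1 nM
- compound 3 `Cc1cc(C)c2c(O)cc(-c3cccc(Cl)c3)nc2n1`: 347 nM

Compound 3 has the highest number of the three, 347 nM, and so the weakest growth inhibition so far. Compound 4 `Cc1cccc(-c2cc(O)c3c(C)cc(C)nc3n2)c1` differs from it in a single group: methyl in place of chloro on an aromatic carbon. The swap is methyl in place of chloro on an aromatic carbon.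

One measured step involves the same place on the ring: a 4.1-fold higher number from compound 2 to compound 3 (0.61 log units; beyond the scatter). That modest change was chloro in place of fluoro, so it shows that this place can shift the number, but it does not test methyl. A second clue is compound 1, which has methyl at that place on a somewhat different core and gives 97.7 nM.

Together these point to a modest move towards stronger inhibition in this assay, though no measured step tests this swap directly. The expected step is a 2.3-fold lower number from compound 3 to compound 4 (0.36 log units; beyond the scatter). Compound 4 is estimated at 150 nM, with an expected range of 55 nM to 400 nM.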

Compound 4, concentration for 50% growth inhibition: 38000 nM
Estimate against measurement, compound 4: 250-fold (2.40 log units) below; the whole stated range lies below it.
By their numbers in this assay, from the lowest: compounds 2 and 1 (each within the scatter of the next); then compound 3; then compound 4.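

In this assay this place on the ring proves far more sensitive than the swap of fluoro for chloro suggested: on the shared core, methyl in place of chloro gives a 110-fold higher number from compound 3 to compound 4 (2.04 log units; beyond the scatter) and methyl in place of fluoro gives a 450-fold higher number from compound 2 to compound 4 (2.65 log units; beyond the scatter) on the same read-out. This methyl is not poor in every setting, since compound 1 carries it on a core with one methyl fewer, and adding that core methyl gives a 390-fold higher number from compound 1 to compound 4 (2.59 log units; beyond the scatter) in the step to the weakest of the four; among these compounds, the large loss appears only where both methyls occur together. Nothing shown here explains this loss.

Still open, from the compounds shown here alone, is how other groups at this place behave on the core of compound 4. An ethyl, a methoxy or an amine there could show whether the loss is confined to methyl.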